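The source may report more compounds than this note shows. Statements on the series, on what has been measured and on what is new or still open speak of the compounds shown alone.

Of the compounds shown here, three have been measured in an ADME assay on WI-38 cells (Homo sapiens) for inhibition, read by CellTiter-Glo, with a stated time of 48 h, tested at 100 uM; on this read-out lower numbers stand for less inhibition and higher numbers for more inhibition at the one concentration tested (going by the name of the read-out). Compound 1, `CC(C)(CO)[C@H](O)C(=O)N/C=C/C(=O)OCc1ccccc1`, gives 19%. Compound 2, `CC(C)(C)OC(=O)/C=C/NC(=O)[C@H](O)C(C)(C)CO`, gives 0%. Compound 3, `CC(C)(C)OC(=O)/C=C\NC(=O)[C@@H](O)C(C)(C)CO`, gives 26%. On these numbers compound 3 has the largest reading of the three, but the gap to compound 1 is within the usual scatter, so the two cannot be ranked against each other; only the gap to compound 2 is clear, a step of a number 26 percentage points higher from compound 2 to compound 3 (beyond the scatter), which goes with the fact that compounds 2 and 3 differ only in the configuration as drawn.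

Compound 4, `CC(C)(CO)[C@H](O)C(=O)N/C=C\C(=O)OCc1ccccc1`, is the next compound, not yet measured. It differs from compound 3 in one place: benzyl in place of tert-butyl on an oxygen next to a carbonyl group. Within the data shown here, no measured step covers exactly this swap. The closest hint is the pair compound 1 and compound 2. The benzyl compound, compound 1, gives 19%. The tert-butyl compound, compound 2, gives 0%. This is a gap beyond the scatter but not a step measured between compounds that share the drawn configuration of compound 4. The expectation for compound 4 is therefore a step of a number 6 percentage points higher from compound 3 to compound 4 (within the scatter) in this assay, an estimated value of 32% with a range from 12% to 55%.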

Compound 4, a percentage reported as inhibition, at one concentration (the size of the read-out at that concentration, not a potency): -2%
Compound 4: middle estimate off by 34 percentage points, on the high side, and the stated range ends above it.
By their numbers in this assay, from the lowest: compounds 4 and 2 (each within the scatter of the next); then compounds 1 and 3 (each within the scatter of the next).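

With the double bond drawn Z, benzyl in place of tert-butyl on an oxygen next to a carbonyl group can now be read directly, and in this assay the swap gives a number 28 percentage points lower from compound 3 to compound 4 (beyond the scatter). A second new step keeps the benzyl group and changes only the double bond, from E to Z, giving a number 21 percentage points lower from compound 1 to compound 4 (beyond the scatter). The earlier a number 26 percentage points higher from compound 2 to compound 3 (beyond the scatter) came with both stereo elements differing at once, so the new step shows that the double bond alone can move this reading: the fact that compounds 1 and 4 differ only in the configuration as drawn

Going by these compounds, compounds 2 and 3 cannot separate the double bond from the stereocentre, so the share of each with tert-butyl stays unknown. The compounds shown also do not tell what an ethyl group on that oxygen, or a free carboxylic acid in place of the ester, would give.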